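A few compounds are considered here, and "the series" means these few. Any claim that something is new, unique, unknown or untested is made for them only; others in the source may bear on it.

In a functional assay on the whole organism with Scenedesmus acutus as the target, with a stated time of 20 h (a lower number here means a stronger inhibitor, a higher number a weaker inhibitor), compound 3 `CC(C)COC(=O)c1cc(N2C(=O)C3=C(CCCC3)C2=O)c(F)cc1Cl` gives 407 nM, the highest number of the three measured. Compound 1 `CCOC(=O)c1cc(N2C(=O)C3=C(CCCC3)C2=O)c(F)cc1Cl` gives 87.1 nM and compound 2 `CCCCOC(=O)c1cc(N2C(=O)C3=C(CCCC3)C2=O)c(F)cc1Cl` gives 141 nM. Compound 4 `C#CCOc1cc(N2C(=O)C3=C(CCCC3)C2=O)c(F)cc1Cl` differs from compound 3 by propargyloxy in place of isobutoxycarbonyl on an aromatic carbon, with propargyloxy in place of isobutoxycarbonyl on an aromatic carbon. The measured steps alter only the ester chain: a 1.6-fold higher number from compound 1 to compound 2 (0.21 log units; within the scatter), a 4.7-fold higher number from compound 1 to compound 3 (0.67 log units; beyond the scatter) and a 2.9-fold higher number from compound 2 to compound 3 (0.46 log units; beyond the scatter). None of them removes the ester, so they guide this change only loosely. Compound 3 holds the highest number, so a modest move to a lower number in this assay is expected, similar in size to the larger of these steps. The expected change is a 3.4-fold lower number from compound 3 to compound 4 (0.53 log units; beyond the scatter). Compound 4 is estimated at 120 nM, with an expected range of 25 nM to 600 nM.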

Compound 4, half-maximal inhibitory concentration: 141 nM
The estimate for compound 4 lay 1.2-fold (0.07 log units) below the measured number; the range from low to high includes it.
By their numbers in this assay, from the lowest: compounds 1, 2 and 4 (each within the scatter of the next); then compound 3.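

In this assay, the ester at this aromatic carbon, ortho to a chloro group, can give way to propargyloxy, which has no carbonyl, without the number leaving the range of the esters. The change gives a 2.9-fold lower number from compound 3 to compound 4 (0.46 log units; beyond the scatter) against the isobutyl ester, while the other two comparisons give no change at the digits printed from compound 2 to compound 4 (within the scatter) and a 1.6-fold higher number from compound 1 to compound 4 (0.21 log units; within the scatter) so compound 4 matches the ethyl and butyl esters rather than the isobutyl one. Nothing shown explains these numbers. On these data alone, whether the triple bond matters stays open, as does how an allyloxy group, a methoxy group or a carboxylic acid at this carbon would compare.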